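Benzyl to tert-butyl on the shared core: compounds 3 and 4

The source may report more compounds than this note shows. Statements on the series, on what has been measured and on what is new or still open speak of the compounds shown alone.

Of the compounds shown here, three have been measured in a functional assay on HT-29 cells (Homo sapiens) for cytotoxicity, read by sulforhodamine B assay, with a stated time of 48 h; on this read-out higher numbers stand for weaker inhibition of growth and lower numbers for stronger inhibition of growth. Compound 1 `COC(=O)[C@@H]1C[C@H]2c3ccccc3N3C(=N)[C@](Cc4ccccc4)(N4CCCC4)N1[C@@H]23` gives 7210 nM. Compound 2 `C=CC[C@@]12C[C@@H](C(=O)OC)N3[C@@H]1N(C(=N)[C@]3(Cc1ccccc1)N1CCCC1)c1ccc(Br)cc12` gives 7840 nM. Compound 3 `COC(=O)[C@@H]1C[C@@]2(CC=C(C)C)c3ccccc3N3C(=N)[C@H](Cc4ccccc4)N1[C@H]32` gives 24100 nM, the highest of the three numbers; its gap to compound 2 and its gap to compound 1 both lie beyond the usual scatter, so compound 3 is the weakest inhibitor of growth among the three in this assay. Among the compounds with values here, no single-point step between the measured compounds is available, so nothing in the measured set tells how a change at this position moves the read-out.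

Compound 4 `COC(=O)[C@@H]1C[C@@]2(CC=C(C)C)c3ccccc3N3C(=N)[C@H](C(C)(C)C)N1[C@H]32` differs from compound 3 in one place: tert-butyl in place of benzyl on a saturated ring carbon. The change removes the one aromatic ring of the benzyl group and leaves a branched chain in its place, with no donor or acceptor added or lost. Within the data shown here, with no measured step of this kind to lean on, the step from compound 3 to compound 4 is expected to be small and in the direction of weaker inhibition, possibly within the scatter a 1.2-fold higher number from compound 3 to compound 4 (0.10 log units; within the scatter). For compound 4 in this assay the estimate is 30000 nM, with a range from 10000 nM to 90000 nM.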

Compound 4, concentration for total growth inhibition: > 100000 nM
Compound 4: a limit, no number; the forecaster's own chance of this, stated with the estimate: 15%; at least 3.3-fold (0.52 log units) between middle value and limit.
By their numbers in this assay, from the lowest: compounds 1 and 2 (each within the scatter of the next); then compound 3. At a limit, above all of these: compound 4.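

In this assay compound 4 gives > 100000 nM, which is a limit of the assay and not a number: the limit of > 100000 nM in this assay, at which 1 of the 4 values shown sits.

Within the data shown here, the change of benzyl to tert-butyl on the saturated ring carbon gives the first readable step at this position, an at least 4.1-fold higher number from compound 3 to compound 4 (0.61 log units; beyond the scatter), so the read-out of this series responds to the group held there, even though neither group carries a hydrogen-bond donor or acceptor. Compounds 1, 2 and 3 all carry benzyl at this carbon, so they could not show this, and the step moves towards weaker inhibition of growth by an amount that is bounded on one side only.

This single step does not separate the loss of the aromatic ring from the smaller count of heavy atoms, nor does it show whether any replacement for benzyl keeps growth inhibition in the range of compound 3. From the compounds shown here alone, how a cyclohexylmethyl group, which has a saturated ring in place of the aromatic one, or a phenyl ring, or an amine on a longer chain would read at this carbon remains open.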